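The source may hold more compounds than are shown below. What is called first, only, known or untested is meant among the compounds shown, and "the series" means these compounds.

Measured so far:
compound 1 `O=C(/C(=C\c1ccc(O)cc1)SCc1ccc(Cl)cc1)c1ccc(Br)cc1` — 10000 nM
compound 2 `O=C(/C(=C\c1ccc(O)cc1)SCc1ccc(F)cc1)c1ccc(Br)cc1` — 10000 nM

In a functional assay on DU-145 cells (Homo sapiens) for inhibition, read by trypan blue exclusion, with a stated time of 96 h (on this read-out lower numbers stand for stronger inhibition of growth and higher numbers for weaker inhibition of growth), compound 1 gives 10000 nM and compound 2 gives 10000 nM. For the measured compounds named here, the only measured step, no change at the digits printed from compound 1 to compound 2 (within the scatter), swaps one halogen for another on the same ring and leaves the read-out where it was. Going by the values given here, compound 1 therefore stands level with compound 2, with no measured compound beside these two.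

Compound 3 `COc1ccccc1/C=C(/SCc1ccc(Cl)cc1)C(=O)c1ccc(Br)cc1` differs from compound 1 in a different part of the molecule: 2-methoxyphenyl in place of 4-hydroxyphenyl on a double-bonded chain carbon bound to a double-bonded chain carbon. Among the compounds with values here, no measured pair here touches this position, so the halogen step from compound 1 to compound 2 cannot say how this read-out responds to it. With nothing to lean on, the expected step of no change at the digits printed from compound 1 to compound 3 (within the scatter) is none beyond the scatter, in either direction. On that basis compound 3 is estimated to give 10000 nM in this assay, within a range of 3000 nM to 30000 nM.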

Compound 3, concentration for 50% growth inhibition: 1000 nM
Compound 3: the middle estimate sits 10-fold (1.00 log units) above what was measured, outside the stated range (below it).
By their numbers in this assay, from the lowest: compound 3; then compounds 1 and 2 (each within the scatter of the next).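

In this assay, the aryl group on a double-bonded chain carbon bound to a double-bonded chain carbon proves able to move the read-out: 2-methoxyphenyl in place of 4-hydroxyphenyl gives a 10-fold lower number from compound 1 to compound 3 (1.00 log units; beyond the scatter) and so opens a response that the halogen swap alone did not show. This single change alters two things together, since the oxygen substituent changes from hydroxy to methoxy and its ring number changes from 4 to 2, leaving 0 hydrogen-bond donors on the group where there was 1. Nothing available here accounts for the lower number.

The compounds shown leave open whether the methoxy group or its ring number carries the step, a question that 4-methoxyphenyl and 2-hydroxyphenyl groups would separate. On these data alone, how an amine on that ring would read also remains open.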